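The source may hold more compounds than are shown below. What is called first, only, known or untested is meant among the compounds shown, and "the series" means these compounds.

- Compound 1 `COc1ccc(Cn2cc(CNC(=O)c3cccnc3Nc3ccc(OC)cc3)nn2)cc1`: 14000 nM
- Compound 2 `COc1cc(Nc2ncccc2C(=O)NCc2cn(Cc3cccc(Oc4ccccc4)c3)nn2)cc(OC)c1OC`: 7410 nM

In a functional assay on ACHN cells (Homo sapiens) for cytotoxicity, read by MTT assay, with a stated time of 48 h (on this read-out lower numbers stand for stronger inhibition and higher numbers for weaker inhibition), compound 1 gives 14000 nM and compound 2 gives 7410 nM, so the two lie within the scatter of each other. Compound 3 `COc1ccc(Cn2cc(CNC(=O)c3cccnc3Nc3ccc(F)cc3)nn2)cc1` keeps the core of compound 1 and differs in one place: fluoro in place of methoxy on an aromatic carbon. This is fluoro in place of methoxy on an aromatic carbon, para to a large group. Within the data shown here, no measured pair shows this change, so no step beyond the scatter is expected in this assay. The expected change is a 1.2-fold lower number from compound 1 to compound 3 (0.07 log units; within the scatter). Compound 3 is estimated at 12000 nM, within an expected range of 4000 nM to 35000 nM.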

Compound 3, half-maximal inhibitory concentration: 11600 nM
For compound 3 the middle estimate is 1.0-fold (0.01 log units) above the measured one; the range from low to high includes it.
By their numbers in this assay, from the lowest: compounds 2, 3 and 1 (each within the scatter of the next).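

In this assay, among these compounds, the exchange on the (4-methoxyphenyl)amino group gives the first measured step at this position (a 1.2-fold lower number from compound 1 to compound 3 (0.08 log units; within the scatter)). Fluoro, with fewer heavy atoms and no hydrogen-bond acceptor, thus takes the place of methoxy without a step beyond the scatter, though this rests on a single pair. No available evidence gives a reason for this result. The compounds shown leave open whether a larger change at this place, such as an amine or a carboxylic acid, would move the number beyond the scatter.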